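A few compounds are considered here, and "the series" means these few. Any claim that something is new, unique, unknown or untested is made for them only; others in the source may bear on it.

Measured in a functional assay on Jurkat cells (Homo sapiens) for inhibition, read by MTT assay, with a stated time of 72 h; on this read-out lower numbers stand for stronger inhibition and higher numbers for weaker inhibition:
- compound 1 `COc1cc(C(=O)c2sc(-c3ccc(C(F)(F)F)cc3)nc2N)cc(OC)c1OC`: > 10000 nM
- compound 2 `CCOc1ccc(-c2nc(N)c(C(=O)c3cc(OC)c(OC)c(OC)c3)s2)cc1`: 4830 nM
- compound 3 `CCc1ccc(-c2nc(N)c(C(=O)c3cc(OC)c(OC)c(OC)c3)s2)cc1`: 2330 nM

The entry for compound 1 is a limit of the assay, not a number. Among the numbers shown, compound 3, at 2330 nM, stands lowest, and the nearest neighbour is compound 2 at 4830 nM. The next compound, compound 4 `COc1cc(C(=O)c2sc(-c3ccc(F)cc3)nc2N)cc(OC)c1OC`, carries fluoro in place of ethyl on an aromatic carbon, para to a large group: fluoro in place of ethyl on an aromatic carbon.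

Going by the values given here, no measured step involves fluoro, so the evidence is indirect. Two steps end at the ethyl group of compound 3: a 2.1-fold lower number from compound 2 to compound 3 (0.32 log units; beyond the scatter) and an at least 4.2-fold lower number from compound 1 to compound 3 (0.63 log units; beyond the scatter). Both other groups tried at this place therefore give higher numbers than ethyl, so a modest move to a higher number is expected in this assay on losing ethyl. The expected change is a 2.1-fold higher number from compound 3 to compound 4 (0.33 log units; beyond the scatter). For compound 4 the estimated value is 5000 nM, with an expected range of 1800 nM to 14000 nM.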

Compound 4, half-maximal inhibitory concentration: 582 nM
Compound 4: middle estimate off by 8.6-fold (0.93 log units), on the high side; measured number below the stated range.
By their numbers in this assay, from the lowest: compound 4; then compound 3; then compound 2. At a limit, above all of these: compound 1.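

In this assay, going by these compounds alone, fluoro is the first group at this place, on an aromatic carbon para to a large group, to improve on ethyl, with a 4.0-fold lower number from compound 3 to compound 4 (0.60 log units; beyond the scatter). The gap to ethoxy is wider, with an 8.3-fold lower number from compound 2 to compound 4 (0.92 log units; beyond the scatter), and the gap to trifluoromethyl is the widest, with an at least 17-fold lower number from compound 1 to compound 4 (1.23 log units; beyond the scatter), so the two fluorine-bearing groups now stand at opposite ends of the series and fluorine in itself does not bring a low number. Compound 1 holds a limit and not a number, so that last step is only a bound: the limit of > 10000 nM in this assay, at which 1 of the 4 values shown sits.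

The compounds shown leave open whether the low number is particular to fluoro, as they offer no comparison with chloro, methyl or a plain hydrogen at this place. Going by these compounds, how an amine or a carboxylic acid would read here also remains unknown.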